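A few compounds are considered here, and "the series" means these few. Any claim that something is new, unique, unknown or untested is made for them only; others in the source may bear on it.

Measured compounds:
Compound 1 `CC(C)(C)Cc1c(-c2ccoc2)sc(N)c1C(=O)c1ccc(Cl)cc1` in an assay on CHO cells for displacement of a labelled ligand from adenosine receptor A3 (Homo sapiens), read by scintillation counting, tested at 10 uM; on this read-out higher numbers stand for more inhibition at the one concentration tested (going by the name of the read-out) and lower numbers for less inhibition: 1%
Compound 2 `COc1ccccc1-c1sc(N)c(C(=O)c2ccc(Cl)cc2)c1CC(C)(C)C` in this assay: 1%

Compound 2 stands level with compound 1 at the digits shown: the displacement read for compound 2 in this assay lies within the scatter of that for compound 1, and the one measured step, no change at the digits printed from compound 1 to compound 2 (within the scatter), registers no change. Both values sit at the floor of the read-out.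

Compound 3 `CC(C)(C)Cc1c(Br)sc(N)c1C(=O)c1ccc(Cl)cc1` is the next member; its difference from compound 2 is bromo in place of 2-methoxyphenyl on an aromatic carbon. Going by the values given here, the single step so far exchanges one aromatic group for another at this carbon and moves nothing; no measured step exchanges an aromatic group for a bromo, so that exchange is unmapped. Given that compound 2 and compound 1 both lie at the floor of this assay and the only measured step left the read-out unchanged, no movement beyond the scatter is expected for compound 3, i.e. a step of a number 2 percentage points higher from compound 2 to compound 3 (within the scatter) is estimated. Compound 3 is therefore expected to give about 3% in this assay, with a range from -8% to 15%.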

Compound 3, a percentage reported as inhibition, at one concentration (the size of the read-out at that concentration, not a potency): 1%
Compound 3: the middle estimate sits 2 percentage points above what was measured; the measured number falls inside the stated range.
By their numbers in this assay, from the lowest: compounds 1, 2 and 3 (each within the scatter of the next).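

The new step widens the range of change at this carbon, next to the ring sulfur, from one aromatic group for another to an aromatic ring for a lone halogen. Bromo in place of 2-methoxyphenyl gives (no change at the digits printed from compound 2 to compound 3 (within the scatter)) in this assay, and bromo in place of furan-3-yl gives (no change at the digits printed from compound 1 to compound 3 (within the scatter)). Neither the presence of an aromatic ring at this carbon nor its size therefore registers on this read-out while all three compounds stay at its floor, and no measurement available here offers an explanation for this.

A read-out at the floor at one concentration cannot separate these three groups, so any difference between them in affinity for the receptor remains unresolved. Also open, from the compounds shown here alone, is whether a different kind of group at this carbon, such as a morpholine, a carboxylic acid or a longer alkyl chain, would lift the read-out, or whether a change to the neopentyl group or the (4-chlorophenyl)carbonyl group would be needed first.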